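The compounds below may be only part of what the source reports. "The series", "measured", "known", "first", "only" and "open" are said of these compounds alone.

Compound 1 `COc1ccc(N(C)c2nc(C)nc3ccccc23)cc1OCCC[Se]C#N`: 921 nM
Compound 2 `COc1ccc(N(C)c2nc(C)nc3ccccc23)cc1C(=O)OCCCC[Se]C#N`: 1080 nM
Compound 3 `COc1ccc(N(C)c2nc(C)nc3ccccc23)cc1`: 8 nM

In a functional assay on LoVo cells (Homo sapiens) for inhibition, read by MTT assay, with a stated time of 48 h (a higher number here means a weaker inhibitor, a lower number a stronger inhibitor), compound 3 gives the lowest of the three numbers, 8 nM, clear of both others beyond the scatter. Compound 4 `COc1ccc(N(C)c2nc(C)nc3ccccc23)cc1OCCN` has not yet been measured. It differs from compound 3 by 2-aminoethoxy in place of hydrogen on an aromatic carbon, ortho to a methoxy group.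

Going by the values given here, two measured steps bear on this: a 120-fold lower number from compound 1 to compound 3 (2.06 log units; beyond the scatter) and a 140-fold lower number from compound 2 to compound 3 (2.13 log units; beyond the scatter), both large, each removing a chain from that carbon. The chains themselves differ little, with a 1.2-fold higher number from compound 1 to compound 2 (0.07 log units; within the scatter). Neither chain carries an amino group, so the transfer is uncertain. A large rise in this assay is still expected, perhaps somewhat smaller, and the estimated step is a 50-fold higher number from compound 3 to compound 4 (1.70 log units; beyond the scatter). The estimate for compound 4 is 400 nM, with an expected range of 60 nM to 2000 nM.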

Compound 4, half-maximal inhibitory concentration: 421 nM
Estimate against measurement, compound 4: 1.1-fold (0.02 log units) below, within the range that was stated.
By their numbers in this assay, from the lowest: compound 3; then compound 4; then compounds 1 and 2 (each within the scatter of the next).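

In this assay, 2-aminoethoxy on this aromatic carbon also gives a large step (a 53-fold higher number from compound 3 to compound 4 (1.72 log units; beyond the scatter)), so a large rise does not require selenium in the chain. Against the selenium-bearing chains, the steps are modest (a 2.2-fold lower number from compound 1 to compound 4 (0.34 log units; beyond the scatter); a 2.6-fold lower number from compound 2 to compound 4 (0.41 log units; beyond the scatter)), so most of the gap from compound 3 is shared by all three chains on this carbon.

Going by these compounds, whether a hydroxy or methyl group here, or a carboxylic acid at the chain end, would stay closer to compound 3 remains open. No evidence on the reason for these steps is at hand.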